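This account rests on a few compounds, and the source may have more. Where it says the series, first, only, none or still open, it means among the compounds named here.

The measured compounds in an assay on isolated protein for inhibition of malate dehydrogenase, mitochondrial (Sus scrofa), with stated times of 45 min and 30 min; a higher number here means a weaker inhibitor, a lower number a stronger inhibitor:

Compound 1, `O=S(=O)(Nc1ccc(-c2nc3ccccc3o2)cc1)c1ccccc1F`: in this assay compound 1 gives only a limit, > 63000 nM.
Compound 2, `O=S(=O)(Nc1ccc2oc(-c3ccccc3)nc2c1)c1cccc(Cl)c1`: in this assay compound 2 gives only a limit, > 63000 nM.
Compound 3, `Cc1cccc(S(=O)(=O)Nc2ccc3oc(-c4ccccc4)nc3c2)c1`: in this assay compound 3 gives only a limit, > 63000 nM.

Compound 1 therefore stands nowhere on a scale of numbers: its value is a limit of this assay, and the same is true of the two other compounds, since (the limit of > 63000 nM in this assay, at which 3 of the 3 values shown sit). Going by the values given here, the only step between measured compounds that differ in one place, a step that the two limits leave unreadable from compound 2 to compound 3, lies between two such limits and cannot be read for size or direction.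

Compound 4, `COc1ccc(Cl)cc1S(=O)(=O)Nc1ccc(-c2nc3ccccc3o2)cc1`, has not yet been measured in this assay. It differs from compound 1 by 5-chloro-2-methoxyphenyl in place of 2-fluorophenyl on a sulfonyl sulfur. Among the compounds with values here, no measured step touches the group on the sulfonyl sulfur, so nothing in the measured set bears on this change, and no direction can be taken from the data.

Given that every value so far sits at the limit, compound 4 is expected to show a step that the limit leaves unreadable from compound 1 to compound 4 in this assay, which is to say no readable change. The estimate for compound 4 in this assay is 90000 nM, with a range from 30000 nM to 300000 nM, and most likely again only a limit will be reported.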

Compound 4, half-maximal inhibitory concentration: > 63000 nM
Compound 4: a limit, no number (the forecaster's own chance of this, stated with the estimate: 85%); the middle value does not contradict the limit.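

The step between compound 1 and compound 4 cannot be read, since both give only a limit and no number in this assay: the limit of > 63000 nM in this assay, at which 4 of the 4 values shown sit.

The compounds shown leave open whether any other group on the sulfonyl sulfur, or any change to the shared core, would give a readable number in this assay.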